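This account rests on a few compounds, and the source may have more. Where it says the series, first, only, none or still open, it means among the compounds named here.

Compound 1 `CC#C[C@@H](Cc1nnn[nH]1)c1ccc(OCc2ccc3scc(-c4cccnc4C)c3c2)cc1` sits at the bottom of the measurable range. In an ADME assay on microsomes from liver (Homo sapiens) for metabolic stability (on this read-out higher numbers stand for a longer-lived compound and lower numbers for a shorter-lived compound), compound 1 gives < 0.0667 h, which is a limit of the assay and not a number. Among the measured compounds shown here, the only exact number so far comes from compound 2 `CC#C[C@@H](Cc1nnn[nH]1)c1ccc(OCc2ccc3sc(F)c(-c4ccc(OCCOC)cc4C)c3c2)cc1`, which gives 1.95 h in this assay. Compound 3 `CC#C[C@@H](Cc1nnn[nH]1)c1ccc(OCc2ccc3scc(C4CC4)c3c2)cc1` keeps the core of compound 1 and changes one group, cyclopropyl in place of 2-methylpyridin-3-yl on an aromatic carbon, two ring bonds from the ring sulfur. For the measured compounds named here, no pair of measured compounds isolates this exchange, so any forecast has little to rest on. A modest lengthening is expected, and the estimated step is an at least 2.9-fold higher number from compound 1 to compound 3 (0.47 log units; beyond the scatter). Compound 3 is expected to give 0.2 h in this assay, with an estimated range from 0.07 h to 0.7 h.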

Compound 3, half-life: 0.267 h
Compound 3: middle estimate off by 1.3-fold (0.13 log units), on the low side; low and high end bracket the measured number.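

In this assay, replacing 2-methylpyridin-3-yl with cyclopropyl on this aromatic carbon, two ring bonds from the ring sulfur, gives an at least 4.0-fold higher number from compound 1 to compound 3 (0.60 log units; beyond the scatter). Among the compounds shown here, this is the first single change read at this position, and it shows that the group there can move the half-life of the core of compound 1 by more than the usual scatter. Compound 1 stands at a limit and not a number, so the step has a known minimum but no known full size: the limit of < 0.0667 h in this assay, at which 1 of the 3 values shown sits.

The compounds shown leave open whether the longer half-life follows the loss of the ring nitrogen, the smaller group or the change from an aromatic to a non-aromatic ring. A plain phenyl or a methyl at this place would begin to separate these readings, and an amine would extend the comparison to a different kind of group.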